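Swapping a thiophen-3-yl for an ethynyl on a quinolinone amide

The compounds below may be only part of what the source reports. "The series", "measured", "known", "first", "only" and "open" are said of these compounds alone.

Compound 1: `CC(C)(C)c1ccc(NC(=O)c2cc(=O)[nH]c3cc(Br)ccc23)cc1`, > 20000 nM (a limit)
Compound 2: `COc1ccc2c(C(=O)Nc3cc(F)cc(F)c3)cc(=O)[nH]c2n1`, > 20000 nM (a limit)
Compound 3: `O=C(Nc1cccc(F)c1)c1cc(=O)[nH]c2cc(-c3ccsc3)ccc12`, 4300 nM

Of the compounds shown here, three have been measured in a functional assay on KYSE-410 cells (Homo sapiens) for antiproliferative activity, read by MTT assay, with a stated time of 72 h; a higher number here means a weaker inhibitor, a lower number a stronger inhibitor. Compound 1 reaches only the limit of the assay, > 20000 nM. Compound 2 likewise gives only a limit, > 20000 nM. Going by the values given here, compound 3 is the single compound with a numerical result, 4300 nM. The other two values sit at the limit, as the limit of > 20000 nM in this assay, at which 2 of the 3 values shown sit, records. Compound 3 therefore stands alone on the shown numbers; no measured step connects it to compound 1 or compound 2.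

Compound 4, `C#Cc1ccc2c(C(=O)Nc3cccc(F)c3)cc(=O)[nH]c2c1`, has not yet been measured. It differs from compound 3 in one place: ethynyl in place of thiophen-3-yl on an aromatic carbon. Among the compounds with values here, no step between measured compounds is available to calibrate this change, so the expected size of the move is uncertain. Compound 4 is expected to be a somewhat weaker inhibitor than compound 3, with an estimated step of a 1.9-fold higher number from compound 3 to compound 4 (0.27 log units; within the scatter) that may not exceed the usual scatter. Compound 4 is estimated at 8000 nM in this assay, within a range from 2000 nM to 30000 nM, with a real chance that only a limit is reported.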

Compound 4, half-maximal inhibitory concentration: 9700 nM
Beside the measured number, compound 4's estimate is 1.2-fold (0.08 log units) below it; measured number inside the range.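

In this assay, replacing thiophen-3-yl with ethynyl on this aromatic carbon gives a 2.3-fold higher number from compound 3 to compound 4 (0.35 log units; beyond the scatter), the first measured step among these compounds. It shows that the number at this position responds to the change, yet only modestly: with the five-membered aromatic ring gone and a much smaller group in its place, compound 4 still gives a numerical result rather than a limit. Nothing in the data shown explains this step.

As far as these compounds go, whether an amine or a carboxylic acid on this same carbon would move the number further, and in which direction, remains open. Compound 1 and compound 2 are joined to the others by no step, and their results are limits, not numbers: the limit of > 20000 nM in this assay, at which 2 of the 4 values shown sit.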